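This account rests on a few compounds, and the source may have more. Where it says the series, first, only, none or still open, it means among the compounds named here.

In an ADME assay on MDCK cells (Canis lupus familiaris) for permeability, read by LC-MS, with a stated time of 90 min, tested at 2 uM (a higher number here means that the compound crosses the layer faster, a lower number that the compound crosses the layer more slowly), compound 1 `COC(c1cc(Cl)c2c(c1Cl)C(=O)N(Cc1c(C)cc(C)[nH]c1=O)CC2)C1CCS(=O)(=O)CC1` gives 6.3 10^-6 cm/s; 5.7 10^-6 cm/s (2 entries). Among the compounds with values here, compound 2 `Cc1cc(C)c(CN2CCc3c(Cl)cc([C@H](C)CO)c(Cl)c3C2=O)c(=O)[nH]1` gives 12.4 10^-6 cm/s, the only number it has in this assay, as one further entry yielded no single number. Compound 3 `Cc1cc(C)c(CN2CCc3c(Cl)cc([C@@H](CO)[C@H]4CCCO4)c(Cl)c3C2=O)c(=O)[nH]1` departs from compound 2 in one place: oxolan-2-yl in place of methyl on a saturated chain carbon bound to an aromatic carbon and a saturated chain carbon, with oxolan-2-yl in place of methyl on a saturated chain carbon. Within the data shown here, no measured pair shows this kind of change, so any forecast is tentative. The expected change is a 1.6-fold lower number from compound 2 to compound 3 (0.19 log units; within the scatter), a small downward step that may stay within the usual scatter. For compound 3 the estimated value is 8 10^-6 cm/s, with an expected range of 3.5 10^-6 cm/s to 16 10^-6 cm/s.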

Compound 3, apparent permeability: 8.5 10^-6 cm/s
The estimate for compound 3 lay 1.1-fold (0.03 log units) below the measured number; measured number inside the range.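

At the saturated chain carbon bound to an aromatic carbon and a saturated chain carbon, this assay now has a step in one place: oxolan-2-yl in place of methyl gives a 1.5-fold lower number from compound 2 to compound 3 (0.16 log units; within the scatter). This position therefore takes a five-membered ring of 5 heavy atoms without a step beyond the scatter. Repeat readings give a sense of that scatter: the several entries of compound 1 in this assay, 6.3 10^-6 cm/s; 5.7 10^-6 cm/s (2 entries)

The compounds shown leave open how an amine or a carboxylic acid at this carbon would read. They also leave open whether the opposite stereocentre in the oxolan-2-yl group would read alike.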